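Replacing the 2,3-difluorophenyl group of compound 2

The compounds below may be only part of what the source reports. "The series", "measured", "known", "first", "only" and "open" are said of these compounds alone.

For the measured compounds named here, in an ADME assay on LLC-MK2 cells (Macaca mulatta) for cytotoxicity, read by spectrophotometry and crystal violet staining, with a stated time of 4 days (a higher number here means that more compound is tolerated, a lower number that less compound is tolerated), compound 2 `CC(C)n1ncc2c(C(=O)Nc3cccc(F)c3F)cc(-c3cccs3)nc21` gives 75000 nM, the higher of the two numbers so far, and compound 1 `CC(C)n1ncc2c(C(=O)Nc3cccc(C(N)=O)c3)cc(-c3cccs3)nc21` gives 25000 nM. Compound 3 `CC(C)n1ncc2c(C(=O)Nc3ccncn3)cc(-c3cccs3)nc21` carries pyrimidin-4-yl in place of 2,3-difluorophenyl on an amide-type nitrogen. Going by the values given here, one measured step bears on this change: a 3.0-fold higher number from compound 1 to compound 2 (0.48 log units; beyond the scatter), a modest one that brought in 2,3-difluorophenyl in place of 3-carbamoylphenyl on an amide-type nitrogen. Compound 3 also lacks 2,3-difluorophenyl, so a modest step toward a lower number in this assay is expected, though this single step gives only weak guidance for pyrimidin-4-yl. The estimated step is a 2.1-fold lower number from compound 2 to compound 3 (0.33 log units; beyond the scatter). For compound 3 the expected value is 35000 nM, with an estimated range of 12000 nM to 90000 nM.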

Compound 3, half-maximal cytotoxic concentration: 50000 nM
Estimate against measurement, compound 3: 1.4-fold (0.15 log units) below; low and high end bracket the measured number.
By their numbers in this assay, from the lowest: compounds 1, 3 and 2 (each within the scatter of the next, the first and the last beyond it).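

In this assay the amide-type nitrogen, which carries a carbon-only aromatic ring in compound 1 and compound 2, also takes pyrimidin-4-yl, a six-membered aromatic ring with hetero atoms, and the two steps are a 1.5-fold lower number from compound 2 to compound 3 (0.18 log units; within the scatter) and a 2.0-fold higher number from compound 1 to compound 3 (0.30 log units; within the scatter), each within the scatter. Compound 3 thus lies within the scatter of both compound 1 and compound 2, although those two lie beyond the scatter of each other, so this result does not group it with either. Nothing in hand accounts for these numbers.

Open, as far as these compounds go, is how this place responds to a group without an aromatic ring, such as a carboxylic acid or an amine on a longer chain. Also open, from the compounds shown here alone, is whether pyrimidin-4-yl behaves the same way when other groups on the shared core change.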